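From cyclohexyl to iodo in a growth inhibition series

The compounds below may be only part of what the source reports. "The series", "measured", "known", "first", "only" and "open" are said of these compounds alone.

Measured compounds:
- compound 1 `O=C(CCl)NC(=O)Nc1ccc(C2CCCCC2)cc1`: 1500 nM
- compound 2 `O=C(CCl)NC(=O)Nc1cccc(OC2CCCC2)c1`: 6200 nM

These values come from a functional assay on MCF7 cells (Homo sapiens) for inhibition, read by sulforhodamine B assay, with a stated time of 48 h; a higher number here means a weaker inhibitor of growth, a lower number a stronger inhibitor of growth. Compound 1 has the lower number of the two, and the gap up to compound 2 lies beyond the usual scatter. The next compound to be tested is compound 3 `O=C(CCl)NC(=O)Nc1ccc(I)cc1`, which keeps the core of compound 1 but has iodo in place of cyclohexyl on an aromatic carbon. Among the compounds with values here, the two measured compounds do not form a single-place pair, so the data offer no direct precedent for this exchange. A moderate rise in the number is expected, although a result within the scatter of compound 1 would not be surprising. The expected change is a 2.3-fold higher number from compound 1 to compound 3 (0.37 log units; beyond the scatter). Compound 3 is estimated at 3500 nM, with an expected range of 1300 nM to 10000 nM.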

Compound 3, concentration for 50% growth inhibition: 6800 nM
The estimate for compound 3 lay 1.9-fold (0.29 log units) below the measured number, and the stated range covers the measured number.
By their numbers in this assay, from the lowest: compound 1; then compounds 2 and 3 (each within the scatter of the next).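

In this assay, within the data shown here, the exchange at this aromatic carbon, para to a group of 8 heavy atoms, gives the first direct reading of a change in one place: a 4.5-fold higher number from compound 1 to compound 3 (0.66 log units; beyond the scatter) when iodo replaces cyclohexyl. Within this pair, the six-membered carbon ring therefore goes with stronger growth inhibition than the single iodine atom. The data give no explanation for the step, and this one pair cannot separate the loss of the ring from the arrival of iodine.

Going by these compounds, how a phenyl ring, a tert-butyl group or an amine would read at this same place remains open. Also open, on these data alone, is whether the step from cyclohexyl to iodo would be of similar size with a bromo or methyl group in place of iodo.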